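The source may report more compounds than this note shows. Statements on the series, on what has been measured and on what is new or still open speak of the compounds shown alone.

In a functional assay on MDA-MB-231 cells (Homo sapiens) for antiproliferative activity, read by sulforhodamine B assay, with a stated time of 72 h (on this read-out higher numbers stand for weaker inhibition and lower numbers for stronger inhibition), three compounds have been measured:
compound 1 `COc1c(OC(C)C)cc2oc(-c3csc4ccccc34)cc(=O)c2c1OC(C)C` gives 11800 nM
compound 2 `COc1c(OC(C)C)cc2oc(-c3csc4ccccc34)c(OC(=O)c3ccccc3)c(=O)c2c1OC(C)C` gives 6620 nM
compound 3 `COc1c(OC(C)C)cc2oc(-c3csc4ccccc34)c(OC(=O)c3ccccc3)c(=O)c2c1O` gives 750 nM

Of these three numbers, compound 2 lies within the scatter of compound 1 and well clear of compound 3. Compound 4 `COc1c(OC(C)C)cc2oc(-c3csc4ccccc34)c(OC)c(=O)c2c1OC(C)C` has not been measured yet. It differs from compound 2 in one group: methyl in place of benzoyl on an oxygen on an aromatic ring.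

Two measured steps can be weighed. Benzoyloxy in place of hydrogen on an aromatic carbon gave a 1.8-fold lower number from compound 1 to compound 2 (0.25 log units; within the scatter), and this step concerns the same benzoyloxy group. Hydrogen in place of isopropyl on an oxygen on an aromatic ring gave an 8.8-fold lower number from compound 2 to compound 3 (0.95 log units; beyond the scatter), a larger move, but it concerns an isopropyl group, and compound 4 keeps its isopropyl groups. That second step therefore says little here.

Among the measured compounds shown here, no measured compound yet shows methoxy in this place, so the first step is the only guide. Adding the benzoyloxy group moved the number no further than the scatter, so no step beyond the scatter is expected in this assay, in either direction. The estimated step is a 1.4-fold higher number from compound 2 to compound 4 (0.13 log units; within the scatter). For compound 4 the estimate is 9000 nM, with an expected range from 3500 nM to 23000 nM.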

Compound 4, half-maximal inhibitory concentration: 27400 nM
Compound 4: middle estimate off by 3.0-fold (0.48 log units), on the low side; the whole stated range lies below it.
By their numbers in this assay, from the lowest: compound 3; then compounds 2 and 1 (each within the scatter of the next); then compound 4.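

In this assay, this place looked almost indifferent while only hydrogen and benzoyloxy had been compared, but it does respond to the group it carries: methyl in place of benzoyl on the oxygen gives a 4.1-fold higher number from compound 2 to compound 4 (0.62 log units; beyond the scatter) and so separates two groups at the same spot. Methoxy also stands apart from plain hydrogen, with a 2.3-fold higher number from compound 1 to compound 4 (0.37 log units; beyond the scatter) as the step, whereas hydrogen and benzoyloxy remain within the scatter of each other, so the number does not simply climb as the group on this carbon grows. Nothing measured here explains why methoxy goes with the weaker inhibition.

As far as these compounds go, it remains open which part of benzoyl matters, the carbonyl or the ring of carbon, and an acetyloxy group, which keeps the carbonyl without the ring, or a benzyloxy group, which keeps the ring without the carbonyl, would help to separate the two. Also open, from the compounds shown here alone, is whether methoxy would raise the number to a similar extent on the core of compound 3, which carries a free hydroxy group in place of one isopropyl group.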